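Thiourea series: aryl substitution and antiproliferative potency

The source may hold more compounds than are shown below. What is called first, only, known or untested is meant among the compounds shown, and "the series" means these compounds.

Measured so far in a functional assay on MDA-MB-231 cells (Homo sapiens) for antiproliferative activity, read by MTT assay; a higher number here means a weaker inhibitor, a lower number a stronger inhibitor:
compound 1 `CNC(=O)c1ccc(Oc2cccc(NC(=S)Nc3cc(C(F)(F)F)cc(C(F)(F)F)c3)c2)nc1` gives 2670 nM
compound 2 `CNC(=O)c1ccc(Oc2cccc(NC(=S)Nc3ccc(F)c(C(F)(F)F)c3)c2)nc1` gives 13300 nM
compound 3 `CNC(=O)c1ccc(Oc2cccc(NC(=S)Nc3ccc(F)c(Cl)c3)c2)nc1` gives 28600 nM

Compound 3 stands highest of the three numbers in this assay; compound 2 is nearest, compound 1 furthest. Among the measured compounds shown here, the one step measured within one change is a 2.2-fold higher number from compound 2 to compound 3 (0.33 log units; beyond the scatter), a modest move in the weakening direction. Compound 4 `CNC(=O)c1ccc(Oc2cccc(NC(=S)Nc3ccc(Cl)cc3)c2)nc1` arises from compound 3 by 4-chlorophenyl in place of 3-chloro-4-fluorophenyl on an amide-type nitrogen. For the measured compounds named here, no measured step touches this exact change; the only bearing comes from the chloro-for-trifluoromethyl step, which shows that a smaller halogen set on the aryl group weakened the number. By analogy, compound 4 is expected to move by a 1.4-fold higher number from compound 3 to compound 4 (0.15 log units; within the scatter), a small step further up, if anything. Compound 4 is thus estimated at 40000 nM, with a range from 15000 nM to 100000 nM.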

Compound 4, half-maximal inhibitory concentration: 66500 nM
The estimate for compound 4 lay 1.7-fold (0.22 log units) below the measured number; the measured number falls inside the stated range.
By their numbers in this assay, from the lowest: compound 1; then compound 2; then compound 3; then compound 4.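

In this assay, 4-chlorophenyl in place of 3-chloro-4-fluorophenyl on the amide-type nitrogen gives a 2.3-fold higher number from compound 3 to compound 4 (0.37 log units; beyond the scatter) and leaves compound 4 with the highest number of the series. The aryl group therefore still moves the number beyond the scatter at this weak end of the series. This single change swaps one halogen pattern for another, so fluorine loss and chlorine placement cannot be separated. No available measurement offers an explanation for the step. Open, going by these compounds, is how the number responds to a methoxy group or an amine on this aryl ring.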